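Chalcone series: trifluoromethyl for bromo on the aryl ring

A few compounds are considered here, and "the series" means these few. Any claim that something is new, unique, unknown or untested is made for them only; others in the source may bear on it.

Compound 1 `O=C(/C=C/c1ccc(Br)cc1)c1ccc(-n2ccnc2)cc1` gives 320 nM in an assay on isolated protein for inhibition of Amine oxidase [flavin-containing] B (Homo sapiens) (a lower number here means a stronger inhibitor, a higher number a weaker inhibitor), and stands highest of the two numbers measured; its nearest neighbour is compound 2 `CCOc1ccc(C(=O)/C=C/c2ccc(Br)cc2)cc1`, which gives 210 nM in this assay, the step of a 1.5-fold lower number from compound 1 to compound 2 (0.18 log units; within the scatter). Compound 3 `O=C(/C=C/c1ccccc1F)c1ccc(-n2ccnc2)cc1` gives only a limit, > 10000 nM in this assay. The step of an at least 31-fold higher number from compound 1 to compound 3 (1.49 log units; beyond the scatter) is the one large move in the set, and it rests on (the limit of > 10000 nM in this assay, at which 1 of the 3 values shown sits).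

Compound 4 `O=C(/C=C/c1ccc(C(F)(F)F)cc1)c1ccc(-n2ccnc2)cc1` differs from compound 1 by trifluoromethyl in place of bromo on an aromatic carbon. The change keeps the substituent on the same aromatic carbon, para to a large group, and only swaps the group there, unlike the step to compound 3, which moved the substituent and changed it at once. Among the measured compounds shown here, no measured step tests a swap of this kind at this place, so the nearest guide is the small step of a 1.5-fold lower number from compound 1 to compound 2 (0.18 log units; within the scatter) at the other end of the core. A step within or just beyond the scatter is expected, a 1.6-fold higher number from compound 1 to compound 4 (0.19 log units; within the scatter). Compound 4 is therefore estimated at 500 nM in this assay, with a range from 150 nM to 2000 nM.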

Compound 4, half-maximal inhibitory concentration: > 10000 nM
Compound 4 was reported as a limit; the forecaster's own chance of this, stated with the estimate: 10%; middle value at least 20-fold (1.30 log units) from the limit.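

In this assay compound 4 is reported only as a limit, > 10000 nM. The step of an at least 31-fold higher number from compound 1 to compound 4 (1.49 log units; beyond the scatter) shows that a swap of group alone on this aromatic carbon, para to a large group, is enough for a large loss, whereas the earlier large step to compound 3 changed the substituent and its place at once. How large the loss really is cannot be read, as this step rests on a limit and not on a number: the limit of > 10000 nM in this assay, at which 2 of the 4 values shown sit.

As far as these compounds go, whether chloro, methyl or a nitrile on the same aromatic carbon keeps a value near that of compound 1 stays open. Also open, from the compounds shown here alone, is whether trifluoromethyl in place of bromo gives the same loss with the ethoxy of compound 2 in place of 1H-imidazol-1-yl.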